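Chloro to Nitro: One Change Tried on a Second Chain

A few compounds are considered here, and "the series" means these few. Any claim that something is new, unique, unknown or untested is made for them only; others in the source may bear on it.

Of the compounds shown here, three built on a shared core have so far been measured in a functional assay on THP-1 cells (Homo sapiens) for inhibition, read by sulforhodamine B assay, with a stated time of 48 h, tested at 50 uM; on this read-out higher numbers stand for more inhibition of growth at the one concentration tested and lower numbers for less inhibition of growth. In this assay compound 1 `O=C1C(=O)N(CCCCn2cc(COc3cc(=O)oc4ccccc34)nn2)c2ccc([N+](=O)[O-])cc21` gives 55%. In this assay compound 2 `O=C1C(=O)N(CCCCn2cc(COc3cc(=O)oc4ccccc34)nn2)c2ccc(Cl)cc21` gives 71%. In this assay compound 3 `O=C1C(=O)N(CCCn2cc(COc3cc(=O)oc4ccccc34)nn2)c2ccc(Cl)cc21` gives 78%, and the numbers for compound 3 and compound 2 lie within the usual scatter of one another. Compound 4 `O=C1C(=O)N(CCCn2cc(COc3cc(=O)oc4ccccc34)nn2)c2ccc([N+](=O)[O-])cc21` has not yet been measured.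

Compound 1 and compound 2 differ in a single place: nitro in place of chloro on an aromatic carbon. In this assay this change brought a number 16 percentage points lower from compound 2 to compound 1 (beyond the scatter). Compound 4 stands to compound 3 in the very same way: nitro in place of chloro on an aromatic carbon. The place of the change is described in the same words in both pairs, so it is the same change made on a second core. How the core of compound 3 differs from the core of compound 2 is not broken down here.

Among the measured compounds shown here, the only guide to compound 4 is the one earlier step. A step of similar size is expected from compound 3, so the expectation is a number 16 percentage points lower from compound 3 to compound 4 (beyond the scatter), because the same change gave a number 16 percentage points lower from compound 2 to compound 1 (beyond the scatter) in this assay. Compound 4 is therefore estimated at 62% in this assay, with a likely range from 50% to 74% to allow for the scatter of such single-concentration readings.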

Compound 4, percent growth inhibition at one concentration: 60%
Beside the measured number, compound 4's estimate is 2 percentage points above it, and the stated range covers the measured number.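

Putting nitro in place of chloro on the aromatic carbon brought, in this assay, a number 18 percentage points lower from compound 3 to compound 4 (beyond the scatter), and this step sits close to the one seen earlier on the other core: the same change on two cores in this assay, a number 16 percentage points lower (beyond the scatter) from compound 2 to compound 1 and a number 18 percentage points lower (beyond the scatter) from compound 3 to compound 4, 2 percentage points apart, within the scatter of two such steps

For these two cores, then, the change travels well: knowing its size on one core would have given a fair idea of its size on the other. Among the compounds shown here, this rests on only two pairs of compounds, read in one cell line at a single concentration, so it does not show that the step would keep its size on other cores, and it says nothing about why nitro gives less growth inhibition than chloro here.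

The compounds shown carry only chloro or nitro at this place on the aromatic ring, so it remains open what a fluoro group, a methoxy group or an amine would give there. From the compounds shown here alone, it also remains open whether the chloro-to-nitro step would hold on a core with a longer chain between the two ring systems, or would shrink or grow there.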